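A few compounds are considered here, and "the series" means these few. Any claim that something is new, unique, unknown or untested is made for them only; others in the source may bear on it.

Measured so far in a functional assay on EKVX cells (Homo sapiens) for inhibition, read by sulforhodamine B assay, with a stated time of 48 h; on this read-out higher numbers stand for weaker inhibition of growth and lower numbers for stronger inhibition of growth:

compound 1, `O=CN1CCN(c2ccc(Cl)cc2)C1=S`: 15500 nM
compound 2, `O=CN1CCN(C(=O)c2ccco2)C1=S`: 13700 nM

For the measured compounds named here, only two compounds have been measured in this assay, and both sit in the same region of weak growth inhibition. Compound 1 gives 15500 nM in this assay, and compound 2 gives 13700 nM. The gap between the two lies within the usual scatter of repeated measurements, so compound 1 cannot be set apart from compound 2 on these numbers; neither can be called the more or the less active of the pair.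

The next compound, compound 3, `O=CN1CCN(c2ccc(Cl)c(Cl)c2)C1=S`, differs from compound 1 in a single place: chloro in place of hydrogen on an aromatic carbon. Going by the values given here, no measured pair in this set shows what such a change does in this assay, so there is nothing to lean on beyond the two values above. Among the compounds with values here, with both measured numbers close together and no comparable step on record, the step from compound 1 to compound 3 is expected to be small, most likely within the scatter, with a slight lean towards a lower number. Compound 3 is therefore estimated to give 12000 nM, within a range from 5000 nM to 30000 nM. The expected step of a 1.3-fold lower number from compound 1 to compound 3 (0.11 log units; within the scatter) reflects that modest lean.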

Compound 3, concentration for 50% growth inhibition: 17500 nM
Compound 3: the middle estimate sits 1.5-fold (0.16 log units) below what was measured; the range from low to high includes it.
By their numbers in this assay, from the lowest: compounds 2, 1 and 3 (each within the scatter of the next).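

In this assay, for the compounds shown here, chloro in place of hydrogen on an aromatic carbon, ortho to a chloro group and meta to a group of 8 heavy atoms, gives the first reading for this position: a 1.1-fold higher number from compound 1 to compound 3 (0.05 log units; within the scatter). On the core of compound 1, this position therefore takes one further chloro with no difference that can be told from the scatter, so the added atom leaves compound 3 in the same region of weak growth inhibition. No supporting measurement bears on why this step is so small.

This single step cannot show whether a different group at this position, such as an amine, a carboxylic acid or a longer chain, would move the number beyond the scatter. It also leaves open whether chloro at another carbon of the six-membered aromatic ring, or on a ring lacking the first chloro group, would behave in the same way.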